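A few compounds are considered here, and "the series" means these few. Any claim that something is new, unique, unknown or untested is made for them only; others in the source may bear on it.

Three measured compounds share one core and differ only in the group on a double-bonded chain carbon bound to a double-bonded chain carbon. In an ADME assay on the whole organism for cytotoxicity, with Artemia salina as the target, with a stated time of 24 h (a higher number here means that more compound is needed for the effect, a lower number that less compound is needed), compound 1 `Cc1ccc(S(=O)(=O)NC(=O)Nc2ccccc2C(=O)/C=C/c2ccccc2)cc1` gives 25 ug/mL. Compound 2 `COc1ccc(/C=C/C(=O)c2ccccc2NC(=O)NS(=O)(=O)c2ccc(C)cc2)c(OC)c1` gives 16 ug/mL in this assay, and compound 3 `CCc1cc(/C=C/C(=O)c2ccccc2NC(=O)NS(=O)(=O)c2ccc(C)cc2)cc(OC)c1OC` gives 19.2 ug/mL. Compound 3 stands second highest of the three numbers, and both of its neighbours lie within the scatter: a 1.2-fold higher number from compound 2 to compound 3 (0.08 log units; within the scatter), and a 1.3-fold lower number from compound 1 to compound 3 (0.11 log units; within the scatter). Compound 4 `Cc1ccc(S(=O)(=O)NC(=O)Nc2ccccc2C(=O)/C=C/c2cccc(O)c2)cc1` has not yet been measured; the change from compound 3 is 3-hydroxyphenyl in place of 3-ethyl-4,5-dimethoxyphenyl on a double-bonded chain carbon bound to a double-bonded chain carbon. Among the compounds with values here, the steps that bear on this exchange all swap the group at the same place: a 1.6-fold lower number from compound 1 to compound 2 (0.19 log units; within the scatter), together with the two steps already given. None of them moved the number beyond the scatter, so a further swap at this place is expected to leave the number roughly where it is; the expected step is a 1.1-fold higher number from compound 3 to compound 4 (0.04 log units; within the scatter). Compound 4 is therefore estimated at 21 ug/mL in this assay, with a range from 11 ug/mL to 40 ug/mL.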

Compound 4, concentration for half-maximal effect: 39.3 ug/mL
Compound 4: middle estimate off by 1.9-fold (0.27 log units), on the low side; measured number inside the range.
By their numbers in this assay, from the lowest: compounds 2, 3, 1 and 4 (each within the scatter of the next, the first and the last beyond it).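

In this assay, within the data shown here, this position can move the number after all: 3-hydroxyphenyl gives a 2.0-fold higher number from compound 3 to compound 4 (0.31 log units; beyond the scatter) and, in place of 2,4-dimethoxyphenyl, a 2.5-fold higher number from compound 2 to compound 4 (0.39 log units; beyond the scatter) as the first steps here beyond the scatter, though both are modest. Yet hydroxy in place of hydrogen on an aromatic carbon gives only a 1.6-fold higher number from compound 1 to compound 4 (0.20 log units; within the scatter) and stays within the scatter, so the hydroxy group by itself shows no clear change from plain phenyl. No measurement at hand gives a reason for these shifts.

As far as these compounds go, it stays open whether an amine or a carboxylic acid in place of the hydroxy would carry the number clearly beyond that of plain phenyl. From the compounds shown here alone, it is also open whether a single methoxy group would behave like the two dimethoxy-bearing groups.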